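A few compounds are considered here, and "the series" means these few. Any claim that something is new, unique, unknown or untested is made for them only; others in the source may bear on it.

Measured so far in a functional assay on NCI/ADR-RES cells (Homo sapiens) for inhibition; a higher number here means a weaker inhibitor of growth, a lower number a stronger inhibitor of growth:
- Compound 1 `O=S(=O)(/C=C/c1ccc(F)cc1F)Cc1ccc(Nc2ncnc3ccccc23)cc1`: > 100000 nM, a limit
- Compound 2 `O=S(=O)(/C=C/c1ccc(C(F)(F)F)cc1F)Cc1ccc(Nc2ncnc3cc(Cl)ccc23)cc1`: > 100000 nM, a limit
- Compound 3 `O=S(=O)(/C=C/c1ccc(F)cc1Cl)Cc1ccc(Nc2ncnc3cc(Cl)ccc23)cc1`: > 100000 nM, a limit

None of these entries is a true number. Compound 3 stands with the other two, at the limit of > 100000 nM in this assay, at which 3 of the 3 values shown sit, so all that is known of it is a limit.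

Compound 4 `O=S(=O)(/C=C/c1ccc(F)cc1F)Cc1ccc(Nc2ncnc3cc(Cl)ccc23)cc1` has not yet been measured. It differs from compound 3 in one place, fluoro in place of chloro on an aromatic carbon, ortho to a large group and meta to a fluoro group.

Among the compounds with values here, the one measured step that bears on this change also alters the groups on that same aromatic ring: a step that the two limits leave unreadable from compound 2 to compound 3. It offers no size to carry over. Compound 1 also carries the 2,4-difluorophenyl group, and its entry of > 100000 nM is likewise a limit.

With no readable step in the series, no real shift is expected in this assay from this single exchange. The expected step is a number no higher from compound 3 to compound 4 (the limit leaves the size open), and the data support no direction for it. Compound 4 is estimated at 100000 nM, with an expected range of 40000 nM to 250000 nM, and it will most likely be reported only as a limit.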

Compound 4, concentration for 50% growth inhibition: > 100000 nM
Compound 4 ended at the assay's limit; the forecaster's own chance of this, stated with the estimate: 85%; the middle value sits exactly at the limit.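

Compound 4 gives only a limit in this assay, as do compound 1, compound 2 and compound 3, so none of the steps from these three to compound 4 can be read: the limit of > 100000 nM in this assay, at which 4 of the 4 values shown sit.

The compounds shown leave open whether exchanging chloro, fluoro or trifluoromethyl on an aromatic carbon, or chloro for hydrogen, changes growth inhibition at all.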